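Hydroxy to methylamino on the side chain of compound 2

The source may report more compounds than this note shows. Statements on the series, on what has been measured and on what is new or still open speak of the compounds shown alone.

In a functional assay on MCF7 cells (Homo sapiens) for antiproliferative activity, read by MTT assay, with a stated time of 48 h (a higher number here means a weaker inhibitor, a lower number a stronger inhibitor), compound 2 `C=C(c1ccc(OC)cc1NC(=O)CO)c1ccc(OC)c2c1C=CC(C)(C)O2` gives 590 nM as the reference point for this step. Compound 3 `C=C(c1ccc2c(c1)C=CC(C)(C)O2)c1ccc(OC)cc1NC(=O)CN` at 420 nM lies within the scatter of compound 2. Compound 1 `CNCC(=O)Nc1cc(OC)ccc1C(=O)c1ccc2c(c1)C=CC(C)(C)O2` at 1210 nM gives a higher number, and that gap from compound 2 lies beyond the scatter.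

Compound 4 `C=C(c1ccc(OC)cc1NC(=O)CNC)c1ccc(OC)c2c1C=CC(C)(C)O2` departs from compound 2 in one place, on a saturated chain carbon bound to a carbonyl carbon, where the change reads methylamino in place of hydroxy on a saturated chain carbon bound to a carbonyl carbon and the rest of the structure stays the same. Going by the values given here, no measured pair isolates this change. Compound 1 (at 1210 nM) also carries methylamino but on a different core, so it is only a loose guide.

A large step is not expected in this assay because compound 3 at 420 nM and compound 2 at 590 nM lie within the scatter of each other. The estimated size of the change is a 1.1-fold higher number from compound 2 to compound 4 (0.04 log units; within the scatter) and it is expected to stay small. For compound 4 the estimated value is 650 nM (from 250 nM to 1700 nM).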

Compound 4, half-maximal inhibitory concentration: 1010 nM
Estimate against measurement, compound 4: 1.6-fold (0.19 log units) below; the measured number falls inside the stated range.
By their numbers in this assay, from the lowest: compounds 3, 2, 4 and 1 (each within the scatter of the next, the first and the last beyond it).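

Going by these compounds alone, this is the first pair to isolate the side chain position: on a saturated chain carbon bound to a carbonyl carbon, methylamino in place of hydroxy gives a 1.7-fold higher number from compound 2 to compound 4 (0.23 log units; within the scatter) in this assay. On the shared core of compound 2 and compound 4, the pair therefore does not separate the two groups, although methylamino brings 2 heavy atoms where hydroxy has 1, and nitrogen where hydroxy has oxygen. No supporting measurement accounts for this result.

From the compounds shown here alone, whether dimethylamino, a carboxylic acid or a longer chain at this carbon would give a step beyond the scatter remains open. It also remains open whether the same exchange gives a similar step on the core of compound 1 or the core of compound 3, since neither has its hydroxy counterpart among the compounds shown.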